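A few compounds are considered here, and "the series" means these few. Any claim that something is new, unique, unknown or untested is made for them only; others in the source may bear on it.

Measured compounds:
- compound 1, `Cc1cc(NCCCc2ccccn2)n2nc(C)c(-c3ccccc3)c2n1`: 5900 nM
- compound 2, `Cc1cccc(CNc2cc(C)nc3c(-c4ccccc4)c(C)nn23)n1`: < 5000 nM, a limit of the assay rather than a number

In a physicochemical assay for solubility, read by HPLC, using the shake flask method, measured as kinetic solubility, with a stated time of 2 h, at pH 7.4 (on this read-out higher numbers stand for higher solubility and lower numbers for lower solubility), compound 1 gives 5900 nM, and this is the only number shown. For compound 2 the value < 5000 nM is a limit of the assay (the limit of < 5000 nM in this assay, at which 1 of the 2 values shown sits). The step of an at least 1.1-fold lower number from compound 1 to compound 2 (0.07 log units; that floor lies within the scatter) therefore has a floor that lies within the scatter, and its true size is open.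

Compound 3, `Cc1cc(NCc2nccs2)n2nc(C)c(-c3ccccc3)c2n1`, has not been measured in this assay. It differs from compound 1 by 1,3-thiazol-2-yl in place of 2-(pyridin-2-yl)ethyl on a saturated chain carbon bound to a nitrogen on an aromatic ring. For the measured compounds named here, the only step that bears on this change is the one from compound 1 to compound 2, in which the chain was likewise shortened to a single saturated carbon carrying an aromatic ring and the result fell to a limit. The step of a 1.5-fold lower number from compound 1 to compound 3 (0.17 log units; within the scatter) is therefore expected to be small or slightly downward. Compound 3 is estimated at 4000 nM, within 1500 nM to 9000 nM.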

Compound 3, solubility: 108000 nM
Beside the measured number, compound 3's estimate is 27-fold (1.43 log units) below it; measured number outside the range, above it.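

In this assay, for the compounds shown here, this position proves far more sensitive to the group it carries than the earlier compounds could show, with 1,3-thiazol-2-yl in place of 2-(pyridin-2-yl)ethyl giving an 18-fold higher number from compound 1 to compound 3 (1.26 log units; beyond the scatter). The shorter link seen in compound 2 thus does not by itself fix the read-out, for exchanging 6-methylpyridin-2-yl for 1,3-thiazol-2-yl on the same carbon gives an at least 21-fold higher number from compound 2 to compound 3 (1.33 log units; beyond the scatter). Compound 2 stands at a limit and not a number, so that second step is only a floor: the limit of < 5000 nM in this assay, at which 1 of the 3 values shown sits.

The compounds shown give no cause for the rise, and they do not separate the sulfur of the 1,3-thiazol-2-yl from its ring nitrogen or from the size of the ring. A plain pyridin-2-yl or a 1,3-oxazol-2-yl on the same carbon would bear on that question.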